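Two compounds and an imine methyl swap

A few compounds are considered here, and "the series" means these few. Any claim that something is new, unique, unknown or untested is made for them only; others in the source may bear on it.

Compound 1 `CCO/C=N/c1c(C#N)ncn1Cc1ccccc1`: 2%
Compound 2 `Cc1ccc(-c2ncc3[nH]c(=O)n(Cc4ccccc4)c3n2)cc1`: 2.6%

In an assay on HEK293 cells for displacement of a labelled ligand from adenosine receptor A2b (Homo sapiens), read by scintillation counting, with a stated time of 30 min, tested at 10 uM (a lower number here means less inhibition, a higher number more inhibition at the concentration tested (going by the name of the read-out)), compound 1 gives 2%, and compound 2 gives 2.6%; the two numbers lie within the usual scatter of each other, so neither stands apart. Compound 3 `CCO/C(C)=N/c1c(C#N)ncn1Cc1ccccc1` differs from compound 1 by a group of 6 heavy atoms (4 carbon, 1 nitrogen, 1 oxygen; no ring) in place of a group of 5 heavy atoms (3 carbon, 1 nitrogen, 1 oxygen; no ring), on an aromatic carbon. For the measured compounds named here, no measured pair shows what such a change does here, so a step no larger than the scatter, in either direction, is expected. Compound 3 is therefore estimated at 3%, with a range from -8% to 15%, an expected step of a number 1 percentage points higher from compound 1 to compound 3 (within the scatter).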

Compound 3, a percentage reported as inhibition, at one concentration (the size of the read-out at that concentration, not a potency): 9.9%
Compound 3: middle estimate off by 6.9 percentage points, on the low side; the range from low to high includes it.
By their numbers in this assay, from the lowest: compounds 1, 2 and 3 (each within the scatter of the next).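

For the compounds shown here, this is the first measured pair at this position. In this assay, a group of 6 heavy atoms in place of a group of 5 heavy atoms, on an aromatic carbon of the five-membered ring, gives a number 7.9 percentage points higher from compound 1 to compound 3 (within the scatter) and so shows no clear effect of this small change. No measurement on hand offers an explanation for the result.

From the compounds shown here alone, whether an amine, a carboxylic acid or a longer chain on this same carbon would move the number beyond the scatter remains open.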